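Swapping the aryl group on a hydrazide core

The compounds below may be only part of what the source reports. "The series", "measured", "known", "first", "only" and "open" are said of these compounds alone.

Compound 1 `Cc1ccc(C(=O)NNC(=O)c2ccc(NS(=O)(=O)c3cnc(O)nc3O)cc2)cc1` carries a 4-methylphenyl on a carbonyl carbon whose other neighbour is an amide-type nitrogen. In a functional assay on A549 cells (Homo sapiens) for antiproliferative activity, read by MTT assay, with a stated time of 24 h (a lower number here means a stronger inhibitor, a higher number a weaker inhibitor), compound 1 gives 15900 nM. Compound 2 `O=C(NNC(=O)c1ccccc1Cl)c1ccc(NS(=O)(=O)c2cnc(O)nc2O)cc1` differs from it only through (2-chlorophenyl in place of 4-methylphenyl on a carbonyl carbon); in this assay compound 2 gives 1900 nM, which is an 8.4-fold lower number from compound 1 to compound 2 (0.92 log units; beyond the scatter). Compound 3 `Cc1ccc(C(=O)NNC(=O)c2cccc(NS(=O)(=O)c3cnc(O)nc3O)c2)cc1` has the same atoms as compound 1, joined differently; the difference between the two cores is not broken down here. In this assay compound 3 reaches only a limit of the assay, > 20000 nM, which is the limit of > 20000 nM in this assay, at which 1 of the 3 values shown sits. Compound 4 `O=C(NNC(=O)c1ccccc1Cl)c1cccc(NS(=O)(=O)c2cnc(O)nc2O)c1` arises from compound 3 by 2-chlorophenyl in place of 4-methylphenyl on a carbonyl carbon, at a place described in the same words, so this is the same change. Beside an 8.4-fold lower number from compound 1 to compound 2 (0.92 log units; beyond the scatter), the expected step is an at least 4.0-fold lower number from compound 3 to compound 4 (0.60 log units; beyond the scatter), an expectation resting on that measured pair. Compound 4 is accordingly expected to give 5000 nM.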

Compound 4, half-maximal inhibitory concentration: 3740 nM
Estimate against measurement, compound 4: 1.3-fold (0.13 log units) above; measured number inside the range.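

In this assay the step on the core of compound 3 is an at least 5.3-fold lower number from compound 3 to compound 4 (0.72 log units; beyond the scatter) for 2-chlorophenyl in place of 4-methylphenyl on a carbonyl carbon, so the change lowers the number here as it did on the core of compound 1. As far as these compounds go, compound 3 gives > 20000 nM as a limit of the assay and not a number, so the full size of this step is unknown. The direction of the change carries over from one core to the other, but it remains unsettled whether its size does: the same change on two cores in this assay, an 8.4-fold lower number (0.92 log units; beyond the scatter) from compound 1 to compound 2 and an at least 5.3-fold lower number (0.72 log units; beyond the scatter) from compound 3 to compound 4; the limit leaves it open whether they differ.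

The compounds shown compare only these two aryl groups. They leave open how a pyridine ring, an amine or a carboxylic acid in that place would fare on either core.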